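From Benzoyloxy to Formylamino: a Cytotoxicity Expectation

The source may hold more compounds than are shown below. What is called first, only, known or untested is meant among the compounds shown, and "the series" means these compounds.

Compound 1 `CCN1CCN(C[C@H]2CN(c3ccc(-n4cc(-c5ccccn5)cn4)c(F)c3)C(=O)O2)CC1`: 99 ug/mL
Compound 2 `CC(=O)OC[C@H]1CN(c2ccc(-n3cc(-c4ccccn4)cn3)c(F)c2)C(=O)O1`: > 400 ug/mL
Compound 3 `O=C(OC[C@H]1CN(c2ccc(-n3cc(-c4ccccn4)cn3)c(F)c2)C(=O)O1)c1ccccc1`: > 400 ug/mL

In an ADME assay on HEK293-A cells (Homo sapiens) for cytotoxicity, read by MTT assay, with a stated time of 48 h (a higher number here means a weaker inhibitor, a lower number a stronger inhibitor), compound 1 gives 99 ug/mL. Compound 2 reaches only the limit of the assay, > 400 ug/mL. Compound 3 likewise stops at a limit, > 400 ug/mL, so its standing is known only as a bound. The steps of an at least 4.0-fold higher number from compound 1 to compound 2 (0.60 log units; beyond the scatter) and an at least 4.0-fold higher number from compound 1 to compound 3 (0.60 log units; beyond the scatter) both end at the limit of > 400 ug/mL in this assay, at which 2 of the 3 values shown sit, while a step that the two limits leave unreadable from compound 2 to compound 3. Compound 4 `O=CNC[C@H]1CN(c2ccc(-n3cc(-c4ccccn4)cn3)c(F)c2)C(=O)O1` carries formylamino in place of benzoyloxy on a saturated chain carbon bound to a saturated ring carbon. Going by the values given here, no measured step covers an ester-to-amide change, so the expectation rests on the two ester limits alone. Compound 4 is expected at 400 ug/mL, within 150 ug/mL to 800 ug/mL. The expected step is a number no higher from compound 3 to compound 4 (the limit leaves the size open).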

Compound 4, half-maximal inhibitory concentration: > 400 ug/mL
Compound 4 ended at the assay's limit (the forecaster's own chance of this, stated with the estimate: 70%); the middle value lies on the limit itself.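

In this assay compound 4 also gives only a limit, > 400 ug/mL. On the saturated chain carbon bound to a saturated ring carbon, the limit is therefore no longer seen with the two esters alone: formylamino, which carries a hydrogen-bond donor, reaches it too, and replacing 4-ethylpiperazin-1-yl gives an at least 4.0-fold higher number from compound 1 to compound 4 (0.60 log units; beyond the scatter). The steps among compound 2, compound 3 and compound 4 cannot be read, as all three stop at the same limit: the limit of > 400 ug/mL in this assay, at which 3 of the 4 values shown sit.

From the compounds shown here alone, how far these three lie apart remains open. So does whether a primary amine or a morpholine on this carbon would fall nearer compound 1 or stay at the limit.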